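The compounds below may be only part of what the source reports. "The series", "measured", "known", "first", "only" and "open" are said of these compounds alone.

Measured so far in a functional assay on HepG2 cells (Homo sapiens) for inhibition, read by MTT assay, with a stated time of 48 h, tested at 10 uM; a lower number here means less inhibition of growth, a higher number more inhibition of growth at the concentration tested:

Compound 1 `COc1ccc(C(=O)/C=C/c2ccc(OCc3cn(Cc4ccc(Br)cc4)nn3)cc2)cc1`: 59%
Compound 2 `COc1ccc(C(=O)/C=C/c2ccc(OCc3cn(Cc4cccc(F)c4)nn3)cc2)cc1`: 22%

Compound 2 stands lowest of the two numbers in this assay. For the measured compounds named here, its nearest neighbour is compound 1, and the one step between them, a number 37 percentage points lower from compound 1 to compound 2 (beyond the scatter), is a large one.

Compound 3 `O=C(/C=C/c1ccc(OCc2cn(Cc3cccc(F)c3)nn2)cc1)c1ccc([N+](=O)[O-])cc1` has not yet been measured in this assay. It differs from compound 2 in one place: nitro in place of methoxy on an aromatic carbon. Going by the values given here, the only measured step, from compound 1 to compound 2, concerns a different part of the shared core, the substituted phenyl on the saturated chain carbon bound to an aromatic nitrogen, and so does not bear on the exchange of methoxy for nitro. Among the compounds with values here, no measured pair shows what this exchange does in this assay. The expectation for compound 3 therefore rests on compound 2 alone, with no step beyond the scatter foreseen either way, and a wide range around it. Compound 3 is expected to give 30% in this assay, between 8% and 58%, which means an expected step of a number 8 percentage points higher from compound 2 to compound 3 (within the scatter).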

Compound 3, percent growth inhibition at one concentration: 43%
Compound 3: middle estimate off by 13 percentage points, on the low side, and the stated range covers the measured number.
By their numbers in this assay, from the lowest: compound 2; then compound 3; then compound 1.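

In this assay, putting nitro in place of methoxy gives a number 21 percentage points higher from compound 2 to compound 3 (beyond the scatter), so a change at this position, para to a large group, can alter growth inhibition at the concentration tested. For the compounds shown here, until now, the only step concerned a different part of the shared core, the substituted phenyl on the saturated chain carbon bound to an aromatic nitrogen, so two separate places on the molecule are now seen to affect this number. Nothing available here explains why the exchange of 4-methoxyphenyl for 4-nitrophenyl raises the number.

A single exchange cannot separate the effect of losing methoxy from that of gaining nitro, and a compound with an amine or a carboxylic acid at this position would give further points of comparison. From the compounds shown here alone, it also remains open whether the step would keep its direction and size alongside 4-bromophenyl, as this methoxy and nitro pair appears here only with 3-fluorophenyl on the other part of the shared core.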